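A dimethoxyphenyl swap at the assay limit

This account rests on a few compounds, and the source may have more. Where it says the series, first, only, none or still open, it means among the compounds named here.

- Compound 1 `COc1ccc(/C=C/C(=O)/C=C/c2cc3ccccc3nc2Oc2ccccc2)cc1OC` gives > 10000 nM (a limit)
- Compound 2 `COc1ccc(/C=C/C(=O)/C=C/c2cc3ccccc3nc2Oc2ccc(Br)cc2)cc1` gives > 10000 nM (a limit)
- Compound 3 `COc1ccc(OC)c(/C=C/C(=O)/C=C/c2cc3ccccc3nc2Oc2ccc(Br)cc2)c1` gives > 10000 nM (a limit)

All three compounds were tested in a functional assay on NCI-H460 cells (Homo sapiens) for cytotoxicity, read by MTT assay, with a stated time of 48 h (a lower number here means a stronger inhibitor, a higher number a weaker inhibitor), and none returned a number. Compound 3 stands at > 10000 nM (a limit, not a number). It shares this position with the other two compounds (the limit of > 10000 nM in this assay, at which 3 of the 3 values shown sit).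

Compound 4 `COc1ccc(/C=C/C(=O)/C=C/c2cc3ccccc3nc2Oc2ccc(Br)cc2)cc1OC` has not yet been measured. It differs from compound 3 in one place (3,4-dimethoxyphenyl in place of 2,5-dimethoxyphenyl on a double-bonded chain carbon bound to a double-bonded chain carbon), with 3,4-dimethoxyphenyl in place of 2,5-dimethoxyphenyl on a double-bonded chain carbon bound to a double-bonded chain carbon. The two compounds have the same atoms, joined differently.

Among the compounds with values here, only one measured step bears on this change, the one that leads to compound 3 (a step that the two limits leave unreadable from compound 2 to compound 3). Its size cannot be read, so it offers no measure for the new exchange. No step beyond the scatter is therefore expected in this assay, and no direction can be given. A further limit is the most likely report. The expected step is a step that the limit leaves unreadable from compound 3 to compound 4 and is only an estimate. For compound 4 the estimated value is 12000 nM with an expected range from 4000 nM to 30000 nM in this assay.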

Compound 4, half-maximal inhibitory concentration: > 10000 nM
Compound 4 was reported as a limit; the forecaster's own chance of this, stated with the estimate: 70%; the middle value lies beyond the limit too.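

In this assay compound 4 gives > 10000 nM, which is a limit. No step from compound 1, compound 2 or compound 3 to compound 4 can therefore be read: the limit of > 10000 nM in this assay, at which 4 of the 4 values shown sit.

The compounds shown leave open whether exchanging the dimethoxyphenyl groups, or adding methoxy or bromo, changes the half-maximal inhibitory concentration at all.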